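This account rests on a few compounds, and the source may have more. Where it says the series, first, only, none or still open, it means among the compounds named here.

In a functional assay (aorta) for inhibition, with Rattus norvegicus as the target (on this read-out lower numbers stand for stronger inhibition and higher numbers for weaker inhibition), compound 1 `Cc1nsc(-c2ccc(N3CCN(c4cccc(C(F)(F)F)c4)CC3)cc2)n1` gives 10 nM and compound 2 `Cc1nsc(-c2ccc(N3CCN(c4cccc(F)c4)CC3)nn2)n1` gives 6 nM. Going by the values given here, these two values lie within the usual scatter of each other, so compound 2 stands level with compound 1 on the numbers so far. The next compound, compound 3 `COc1cccc(N2CCN(c3ccc(-c4nc(C)ns4)nn3)CC2)c1`, changes a single place in compound 2: methoxy in place of fluoro on an aromatic carbon. In words, methoxy sits in place of fluoro on an aromatic carbon, turning 3-fluorophenyl into 3-methoxyphenyl. Among the compounds with values here, no two measured compounds differ in one place only, so no measured step shows what this swap does. The expectation therefore starts from compound 2 at 6 nM and allows only a modest shift. The expected step, a 1.7-fold higher number from compound 2 to compound 3 (0.22 log units; within the scatter), is small, towards weaker inhibition, and within the scatter. For compound 3 the estimated value is 10 nM, with an expected range of 3 nM to 35 nM.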

Compound 3, half-maximal inhibitory concentration: 7 nM
For compound 3 the middle estimate is 1.4-fold (0.15 log units) above the measured one, within the range that was stated.
By their numbers in this assay, from the lowest: compounds 2, 3 and 1 (each within the scatter of the next).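

In this assay, going by these compounds alone, putting methoxy in place of fluoro on this aromatic carbon gives a 1.2-fold higher number from compound 2 to compound 3 (0.07 log units; within the scatter), and this is the first one-place step measured in this set. So at this position, meta to a large group, the change from 3-fluorophenyl to 3-methoxyphenyl produces no difference that can be told apart from repeat scatter, even though methoxy has more heavy atoms than fluoro and adds a hydrogen-bond acceptor. No separate measurement is available to explain why the number stays level.

As far as these compounds go, with only these two groups compared at this position, it remains open whether an amine, a carboxylic acid or a longer chain such as butoxy would also keep the number level. From the compounds shown here alone, whether the same swap would behave alike on a different core also remains open.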